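Demethylating the methoxyethyl amide of compound 1

The source may hold more compounds than are shown below. What is called first, only, known or untested is meant among the compounds shown, and "the series" means these compounds.

Compound 1 `COCCNC(=O)c1cc2cccc(OC)c2oc1=O`: in an assay on CHO cells for displacement of a labelled ligand from adenosine receptor A1 (Homo sapiens), read by scintillation counting, with a stated time of 60 min, tested at 10 uM (a lower number here means less inhibition, a higher number more inhibition at the concentration tested (going by the name of the read-out)), compound 1 gives 45%
Compound 2 `COc1cccc2cc(C(=O)Nc3c(C#N)ncn3-c3ccc(C#N)cc3)c(=N)oc12`: in this assay compound 2 gives 18%
Compound 3 `CCC(CO)NC(=O)c1cc2cc(Cl)ccc2oc1=N`: in this assay compound 3 gives 7%

Three measured compounds share an amide-bearing bicyclic core, and compound 1 stands highest of the three in this assay. Its nearest neighbour on the numbers is compound 2, which lies beyond the usual scatter below it, and compound 3 lies further below still, also beyond the scatter. Among the measured compounds shown here, no pair among the measured compounds differs in only one place, so no single structural step can be read from them directly.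

The unmeasured compound 4 `COc1cccc2cc(C(=O)NCCO)c(=O)oc12` is compound 1 with one small change: hydrogen in place of methyl on an oxygen on a saturated carbon

For the measured compounds named here, no measured step speaks to this kind of change, so the expectation rests on the size of the change alone, a single carbon removed from a chain. The step is expected to be small, downward if anything, and probably not beyond the scatter: a number 7 percentage points lower from compound 1 to compound 4 (within the scatter). Compound 4 is therefore estimated to give 38% in this assay, with a range from 20% to 55%.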

Compound 4, a percentage reported as inhibition, at one concentration (the size of the read-out at that concentration, not a potency): 12%
Beside the measured number, compound 4's estimate is 26 percentage points above it, outside the stated range (below it).
By their numbers in this assay, from the lowest: compounds 3, 4 and 2 (each within the scatter of the next, the first and the last beyond it); then compound 1.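

In this assay, replacing methyl with hydrogen on the oxygen on a saturated carbon, which turns the 2-methoxyethyl amide into a 2-hydroxyethyl amide, gives a number 33 percentage points lower from compound 1 to compound 4 (beyond the scatter). Among the compounds shown here, this is the first step in the set that can be read for a change in one place, and it shows that the read-out at this concentration is sensitive to this part of the amide chain: the loss of a single carbon, methoxy to hydroxy, is enough to carry the number beyond the scatter. Nothing available accounts for the size of this step.

What the compounds shown leave open is whether the result depends on the methyl itself or on the ether oxygen, and how an ethoxy group, an amine, a carboxylic acid or a longer chain in place of the methoxy would read in this assay. They also leave open whether the same methoxy to hydroxy change would give a step of this size on a core carrying a chloro group or an imine in place of the carbonyl.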